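A few compounds are considered here, and "the series" means these few. Any claim that something is new, unique, unknown or untested is made for them only; others in the source may bear on it.

Measured so far in an assay on Sf9 cells for inhibition of serine/threonine-protein kinase 4 (Homo sapiens), read by luminescence and ADP-Glo, with a stated time of 1 h, in the presence of a further agent that is not named here; on this read-out higher numbers stand for weaker inhibition and lower numbers for stronger inhibition:
compound 1 `CN1C(=O)C(C2CC2)N(C)c2nc(Nc3ccc(S(N)(=O)=O)cc3)ncc21` gives 136 nM
compound 2 `CC(C)C1C(=O)N(C)c2cnc(Nc3ccc(S(N)(=O)=O)cc3)nc2N1C` gives 254 nM
compound 3 `CN1C(=O)C(CC2CC2)N(C)c2nc(Nc3ccc(S(N)(=O)=O)cc3)ncc21` gives 211 nM

All three share one core and differ only in the group on a saturated ring carbon. Compound 3 sits second highest of the three numbers, yet all three lie within the scatter of one another: a 1.6-fold higher number from compound 1 to compound 3 (0.19 log units; within the scatter), a 1.2-fold lower number from compound 2 to compound 3 (0.08 log units; within the scatter) and a 1.9-fold higher number from compound 1 to compound 2 (0.27 log units; within the scatter). Compound 4 `CN1C(=O)C(c2cccc(C(F)(F)F)c2)N(C)c2nc(Nc3ccc(S(N)(=O)=O)cc3)ncc21` has not been measured; it carries 3-(trifluoromethyl)phenyl in place of cyclopropylmethyl on a saturated ring carbon. The measured steps exchange one small saturated group for another, and none of them moved the number beyond the scatter. The step to compound 4 brings in a 3-(trifluoromethyl)phenyl, a group of a different kind, so those steps bear on it only loosely: they show that the group at this position has so far made little difference, but they do not cover a change of this sort. No step beyond the scatter is expected, though the range of the expectation must be wide. For compound 4 the estimate is 250 nM, between 70 nM and 900 nM, which would be a step of a 1.2-fold higher number from compound 3 to compound 4 (0.07 log units; within the scatter).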

Compound 4, half-maximal inhibitory concentration: 2710 nM
The estimate for compound 4 lay 11-fold (1.04 log units) below the measured number; the whole stated range lies below it.
By their numbers in this assay, from the lowest: compounds 1, 3 and 2 (each within the scatter of the next); then compound 4.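

In this assay, this saturated ring carbon turns out not to accept every group equally: 3-(trifluoromethyl)phenyl gives much weaker inhibition than cyclopropylmethyl (a 13-fold higher number from compound 3 to compound 4 (1.11 log units; beyond the scatter)), isopropyl (an 11-fold higher number from compound 2 to compound 4 (1.03 log units; beyond the scatter)) or cyclopropyl (a 20-fold higher number from compound 1 to compound 4 (1.30 log units; beyond the scatter)). All three steps are large and beyond the scatter, so the near-equal numbers among the three small groups do not extend to this larger aromatic group. No measurement shown here accounts for the loss of inhibition.

On these data alone, it remains open whether the loss comes with the aromatic ring itself or with the trifluoromethyl on it, which an unsubstituted phenyl or a benzyl group would help to separate. Also open, as far as these compounds go, is how this position would respond to a group of another kind, such as an amine or a carboxylic acid.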